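The compounds below may be only part of what the source reports. "The series", "measured", "known", "first", "only" and "open" are said of these compounds alone.

For the measured compounds named here, a small set of compounds built on one shared core gives a first look at how a single substituent swap plays out in an assay on HEK293 cells for inhibition of Leucine-rich repeat serine/threonine-protein kinase 2 (Homo sapiens), read by ELISA, with a stated time of 90 min; a lower number here means a stronger inhibitor, a higher number a weaker inhibitor. Compound 1, with the structure `COc1ccccc1Sc1ccc2nnc(-c3ccccc3)n2n1`, carries a plain phenyl ring on the core, and in this assay compound 1 gives "not determined" (no result reported). Going by the values given here, compound 2, with the structure `COc1ccc(C#N)cc1Sc1ccc2nnc(-c3cnn(C)c3)n2n1`, is the only member with a number: in this assay compound 2 gives 2070 nM, so it stands alone among the values shown, with one further entry that offers no number to compare against.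

Compound 3, with the structure `COc1ccc(Cl)cc1Sc1ccc2nnc(-c3cnn(C)c3)n2n1`, differs from compound 2 in one place: chloro in place of cyano on an aromatic carbon. Among the compounds with values here, no step between two measured compounds is available to show what this kind of swap does here, so the expectation rests on the size of the change alone. Because compound 2 sits at 2070 nM and the swap touches only a single aromatic carbon, the step from compound 2 to compound 3 is expected to be small, a 1.2-fold lower number from compound 2 to compound 3 (0.06 log units; within the scatter), with no clear direction beyond the scatter. Compound 3 is therefore estimated at 1800 nM, within a range from 600 nM to 5000 nM.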

Compound 3, half-maximal inhibitory concentration: 245 nM
The estimate for compound 3 lay 7.3-fold (0.87 log units) above the measured number; the whole stated range lies above it.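

In this assay the aromatic carbon para to a methoxy group clearly responds to what it carries: chloro in place of cyano gives an 8.4-fold lower number from compound 2 to compound 3 (0.93 log units; beyond the scatter) and so stands out from ordinary assay noise. For the compounds shown here, this is the first comparison in the set, and it shows that changing this one group, with the rest of the structure held constant, is enough to shift the number. The swap removes a cyano group, which is counted as a hydrogen-bond acceptor, and brings in a chloro group, which is not, but nothing available here explains why the number moves, and one pair cannot separate the acceptor from any other difference between the two groups.

On these data alone, it remains open how other groups at this same carbon would compare, such as fluoro, methyl, an amine or a carboxylic acid, and whether the order of chloro and cyano would hold for other compounds. Compound 1 has no number, so the plain phenyl ring it carries on the shared core cannot yet be compared with the group found there in the other two compounds.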